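The compounds below may be only part of what the source reports. "The series", "measured", "known", "first", "only" and "open" are said of these compounds alone.

Compound 1 `N#C[Se]c1ccc(NC(=O)Oc2ccc(F)cc2)cc1` gives 41900 nM in a functional assay on CCRF-CEM cells (Homo sapiens) for cytotoxicity, read by MTT assay, with a stated time of 72 h; on this read-out lower numbers stand for stronger inhibition of growth and higher numbers for weaker inhibition of growth. Compound 2 `CCCOC(=O)Nc1ccc([Se]C#N)cc1` gives 38400 nM in this assay. Compound 3 `N#C[Se]c1ccc(NC(=O)Oc2ccccc2)cc1` gives 48000 nM in this assay.

Compound 3 carries the highest of the three numbers, yet its gaps to compound 1 and to compound 2 are both within the scatter, so the three measured compounds cannot be told apart on these data. Compound 4 `N#C[Se]c1ccc(NC(=O)Oc2ccc(Cl)cc2)cc1` differs from compound 3 by chloro in place of hydrogen on an aromatic carbon.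

Going by the values given here, the one measured step that bears on this change is the step from compound 1 to compound 3, a 1.1-fold higher number from compound 1 to compound 3 (0.06 log units; within the scatter), in which a halogen on the same aromatic carbon was exchanged for hydrogen and nothing beyond the scatter followed. The step from compound 2 to compound 3, a 1.3-fold higher number from compound 2 to compound 3 (0.10 log units; within the scatter), concerns a different part of the molecule and was also within the scatter. On that basis no step beyond the scatter in this assay is expected for compound 4. Compound 4 is therefore estimated at 45000 nM in this assay, within a range of 20000 nM to 100000 nM, which means an expected step of a 1.1-fold lower number from compound 3 to compound 4 (0.03 log units; within the scatter).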

Compound 4, concentration for total growth inhibition: 45100 nM
Beside the measured number, compound 4's estimate is 1.0-fold (0.00 log units) below it; the measured number falls inside the stated range.
By their numbers in this assay, from the lowest: compounds 2, 1, 4 and 3 (each within the scatter of the next).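

In this assay, the change of hydrogen to chloro on this aromatic carbon, para to a large group, stays within the scatter (a 1.1-fold lower number from compound 3 to compound 4 (0.03 log units; within the scatter)), and the direct exchange of fluoro for chloro on the same carbon does too (a 1.1-fold higher number from compound 1 to compound 4 (0.03 log units; within the scatter)). Going by these compounds alone, this halogen-for-halogen comparison is what the earlier compounds did not offer, and it shows that hydrogen, fluoro and chloro at this position cannot be told apart on these numbers. No measurement is at hand that would explain this result.

The compounds shown leave open whether a group other than a halogen at this position, such as an amine, a carboxylic acid or a methoxy group, would give a step beyond the scatter. They also leave open whether a longer chain in place of the propyl of compound 2 would do so.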